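The source may hold more compounds than are shown below. What is called first, only, known or untested is meant among the compounds shown, and "the series" means these compounds.

Measured compounds:
- compound 1, `COc1cc(/C=N/c2c(C#N)ncn2-c2ccc(F)cc2)cc(OC)c1OC`, gives 18700 nM in a functional assay on MDA-MB-231 cells (Homo sapiens) for antiproliferative activity, read by MTT assay, with a stated time of 48 h; a lower number here means a stronger inhibitor, a higher number a weaker inhibitor
- compound 2, `COc1ccc(/C=N/c2c(C#N)ncn2-c2ccc(F)cc2)cc1OC`, gives 4270 nM in this assay
- compound 3, `COc1ccc(C2N=C(C(N)=O)c3ncn(-c4ccc(F)cc4)c3N2)cc1`, gives 1220 nM in this assay

Compound 2 and compound 1 share one core and differ in a single spot: methoxy in place of hydrogen on an aromatic carbon. This change gave a 4.4-fold higher number from compound 2 to compound 1 (0.64 log units; beyond the scatter), so the extra methoxy made the compound weaker.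

Compound 3 carries a different core; the difference between the two cores is not broken down here. Compound 3 shows the lowest number of the three, and its nearest neighbour is compound 2.

Compound 4, `COc1ccc(C2N=C(C(N)=O)c3ncn(-c4ccc(F)cc4)c3N2)cc1OC`, has not yet been measured. It differs from compound 3 by methoxy in place of hydrogen on an aromatic carbon. Within the data shown here, this is the same kind of change as the one from compound 2 to compound 1, but not the same: in compound 2 the new methoxy also sits meta to a methoxy group, whereas in compound 3 it does not, and the two cores differ as well.

Because a 4.4-fold higher number from compound 2 to compound 1 (0.64 log units; beyond the scatter) went toward a weaker compound, a weakening of similar direction is expected for compound 4, though its size is uncertain given the different core and surroundings. Compound 4 is therefore estimated to give 2500 nM in this assay, within 800 nM to 7000 nM, which corresponds to an expected step of a 2.0-fold higher number from compound 3 to compound 4 (0.31 log units; beyond the scatter).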

Compound 4, half-maximal inhibitory concentration: 6760 nM
For compound 4 the middle estimate is 2.7-fold (0.43 log units) below the measured one, within the range that was stated.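

In this assay, methoxy in place of hydrogen on an aromatic carbon gave a 5.5-fold higher number from compound 3 to compound 4 (0.74 log units; beyond the scatter), so here the added group, ortho to a methoxy group, went with a weaker compound. Set beside the earlier case, the change moved the number the same way on both cores, and the two steps cannot be told apart in size: the same change on two cores in this assay, a 4.4-fold higher number (0.64 log units; beyond the scatter) from compound 2 to compound 1 and a 5.5-fold higher number (0.74 log units; beyond the scatter) from compound 3 to compound 4, 1.3-fold (0.10 log units) apart, within the scatter of two such steps This shows that, across these two pairs, the cost of the extra methoxy carried over from one core to the other, but it does not show why, and two pairs cannot establish a rule for other cores or for other places on the ring.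

The ring substituents shown here are all methoxy groups, so it remains open whether a hydroxyl, an amine or a chlorine on the same aromatic carbon would move the number in the same direction. On these data alone, it also remains open whether a longer chain such as ethoxy in place of the added methoxy would give a step of similar size on either core.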